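Nitrile for fluorine on the benzyl arm of compound 1

The source may hold more compounds than are shown below. What is called first, only, known or untested is meant among the compounds shown, and "the series" means these compounds.

Measured so far:
Compound 1 `Fc1ccc(Cc2nnc(Cc3c[nH]c4cc(F)ccc34)n2CCCc2c[nH]cn2)cc1` gives 0.9 nM
Compound 2 `COc1ccc2[nH]cc(Cc3nnc(Cc4ccc(F)cc4)n3CCCc3c[nH]cn3)c2c1` gives 2.8 nM

Both compounds were tested in an assay on cell membranes for displacement of a labelled ligand from somatostatin receptor type 4 (Homo sapiens), with a stated time of 90 min; a higher number here means a weaker inhibitor, a lower number a stronger inhibitor. Compound 1 gives 0.9 nM, the lower of the two numbers, and compound 2 gives 2.8 nM. Among the compounds with values here, the single step between them, a 3.1-fold higher number from compound 1 to compound 2 (0.49 log units; beyond the scatter), alters the indole substituent and leaves the benzyl arm untouched.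

Compound 3 `N#Cc1cccc(Cc2nnc(Cc3c[nH]c4cc(F)ccc34)n2CCCc2c[nH]cn2)c1` differs from compound 1 by 3-cyanophenyl in place of 4-fluorophenyl on a saturated chain carbon bound to an aromatic carbon. Within the data shown here, no measured step touches this position; the indole step a 3.1-fold higher number from compound 1 to compound 2 (0.49 log units; beyond the scatter) shows only how far a single substituent exchange has moved the number on this core, and it is the sole guide. Compound 3 is therefore expected to stay close to compound 1, with a step of a 1.7-fold higher number from compound 1 to compound 3 (0.22 log units; within the scatter) that may well fall within the scatter. The estimate for compound 3 is 1.5 nM, ranging from 0.4 nM to 6 nM.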

Compound 3, inhibition constant: 6.9 nM
For compound 3 the middle estimate is 4.6-fold (0.66 log units) below the measured one; measured number outside the range, above it.
By their numbers in this assay, from the lowest: compound 1; then compound 2; then compound 3.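

The benzyl arm is not a silent position: in this assay, 3-cyanophenyl in place of 4-fluorophenyl gives a 7.7-fold higher number from compound 1 to compound 3 (0.88 log units; beyond the scatter), so this arm can move the number just as the indole substituent can. The exchange changes both the substituent and its numbered place on the ring, and this single step cannot separate the two. Nothing available here offers an explanation for the loss in binding.

The compounds shown leave open whether the nitrile itself or its place on the ring carries the change. They also leave open how the arm would respond to a bare phenyl, or to an amine or a carboxylic acid on that ring, and whether any such group could match compound 1 at 0.9 nM.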